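The source may report more compounds than this note shows. Statements on the series, on what has been measured and on what is new or still open speak of the compounds shown alone.

Compound 1 `Cc1nc(OC2CCC2)nc(N2CCC2)c1O` and compound 2 `CCCCCCCCCCCCCCc1nc(OC2CCC2)nc(N2CCC2)c1O` share one core and differ only in the chain attached to it. In a functional assay on cells (Lymphocyte, Homo sapiens), read by a luciferase reporter and ATP content, with a stated time of 48 h, tested at 5 uM (on this read-out lower numbers stand for a stronger effect and higher numbers for a weaker effect at the one concentration tested), compound 1 gives 99%, and in this assay compound 2 gives 105%. On the numbers shown compound 2 stands highest, though its distance from compound 1 lies within the scatter. Compound 3 `CCCCCCCCCCCCCCCCc1nc(OC2CCC2)nc(N2CCC2)c1O` carries ethyl in place of hydrogen on a saturated chain carbon, ten or more bonds along the chain from an aromatic carbon. The two measured compounds differ widely in chain length yet read alike; no step beyond the scatter is expected in this assay. The expected step is a number 2 percentage points lower from compound 2 to compound 3 (within the scatter). Compound 3 is expected to give 103%, between 90% and 115%.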

Compound 3, a percentage reported as activity, at one concentration (the size of the read-out at that concentration, not a potency): 110%
Estimate against measurement, compound 3: 7 percentage points below; the measured number falls inside the stated range.
By their numbers in this assay, from the lowest: compounds 1, 2 and 3 (each within the scatter of the next, the first and the last beyond it).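

In this assay, ethyl in place of hydrogen on a saturated chain carbon, ten or more bonds along the chain from an aromatic carbon, gives a number 5 percentage points higher from compound 2 to compound 3 (within the scatter). This is the one step shown at this place, and it shows that adding an ethyl there does not move the read-out beyond the scatter.

On these data alone, whether an amine or a carboxylic acid on that same saturated chain carbon would read differently in this assay stays open. Nothing shown speaks to the cause of this result.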